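Methylsulfonyl in place of acetyl: working notes on compound 3

The source may report more compounds than this note shows. Statements on the series, on what has been measured and on what is new or still open speak of the compounds shown alone.

Measured so far in an in vitro ADME assay on microsomes from liver (Homo sapiens) for metabolic stability; a lower number here means that the compound disappears faster, a higher number that the compound lasts longer:
- compound 1 `O=C(CO)N1CCC(c2[nH]nc(-c3ccc(Cl)cc3)c2-c2ccncc2)CC1` gives 1.03 h
- compound 2 `CC(=O)N1CCC(c2[nH]nc(-c3ccc(Cl)cc3)c2-c2ccncn2)CC1` gives 1.7 h

Compound 2, at 1.7 h, and compound 1, at 1.03 h, lie within the usual scatter of each other, so the two numbers set no order. For the measured compounds named here, these two compounds do not form a pair that differs in one place, so the series offers no measured step to scale the next change.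

The next compound is compound 3 `CS(=O)(=O)N1CCC(c2[nH]nc(-c3ccc(Cl)cc3)c2-c2ccncn2)CC1`, which differs from compound 2 by one exchange (methylsulfonyl in place of acetyl on an amine nitrogen in a ring). In words, this is methylsulfonyl in place of acetyl on an amine nitrogen in a ring.

Going by the values given here, with no measured precedent for this exchange, no shift beyond the scatter in this assay is expected, and no direction can be favoured. The expectation is anchored on compound 2 at 1.7 h, and the expected move is small (a 1.1-fold lower number from compound 2 to compound 3 (0.03 log units; within the scatter)). For compound 3 the estimated half-life is 1.6 h, with an expected range from 0.8 h to 3.2 h.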

Compound 3, half-life: 0.898 h
Compound 3: the middle estimate sits 1.8-fold (0.25 log units) above what was measured, within the range that was stated.
By their numbers in this assay, from the lowest: compounds 3, 1 and 2 (each within the scatter of the next).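

For the compounds shown here, on the amine nitrogen in the ring, methylsulfonyl in place of acetyl gives a 1.9-fold lower number from compound 2 to compound 3 (0.28 log units; within the scatter) in this assay and provides the first measured step. For this one pair, the effect of the exchange cannot be separated from the variation between repeat measurements, so the half-life gives no reason to rank acetyl and methylsulfonyl at this position. No measurement in hand bears on the size or direction of this step.

As far as these compounds go, whether the half-life responds to any group on this nitrogen remains open, as a single step within the scatter cannot show how a simple alkyl chain, a urea or a chain ending in a carboxylic acid would behave there. The part played by the hydroxyl-bearing acyl group of compound 1 also remains unresolved, as compound 1 differs from compound 2 in more than one place and no single exchange links it to compound 3.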